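Swapping the Aromatic Group for Isopropyl on the Carbonyl

This account rests on a few compounds, and the source may have more. Where it says the series, first, only, none or still open, it means among the compounds named here.

Measured in a functional assay on B16 cells (Mus musculus) for inhibition; on this read-out higher numbers stand for weaker inhibition and lower numbers for stronger inhibition:
- compound 1 `COc1cc(/C=C/C(=O)c2cccc(NC(=O)c3ccco3)c2)ccc1O`: 5.46 ug/mL
- compound 2 `COc1cc(/C=C/C(=O)c2cccc(N)c2)ccc1O`: 11.5 ug/mL
- compound 3 `COc1cc(/C=C/C(=O)c2cccc(NC(=O)c3ccc(Cl)c(Cl)c3)c2)ccc1O`: 3.88 ug/mL

Compound 3 sits at the low end of these numbers, the end of stronger inhibition, and it shares that end with another compound: the data show a 1.4-fold lower number from compound 1 to compound 3 (0.15 log units; within the scatter). The remaining compound stands apart, as the data show a 3.0-fold lower number from compound 2 to compound 3 (0.47 log units; beyond the scatter).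

The next compound is compound 4 `COc1cc(/C=C/C(=O)c2cccc(NC(=O)C(C)C)c2)ccc1O`. It keeps the shared core and has isopropyl in place of 3,4-dichlorophenyl on a carbonyl carbon.

Two kinds of step bear on this change. The closest is the earlier swap on that same carbon, which stayed within the scatter. The other is loss of the whole carbonyl group, which gave a 2.1-fold higher number from compound 1 to compound 2 (0.32 log units; beyond the scatter), a modest step. Among the measured compounds shown here, no measured compound has a group without a ring on this carbon, so the data leave some doubt. A small move towards a higher number in this assay is expected, one that may not clear the scatter. The estimated step is a 1.7-fold higher number from compound 3 to compound 4 (0.22 log units; within the scatter). For compound 4 the expected value is 6.5 ug/mL, with an estimated range from 3.5 ug/mL to 12 ug/mL.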

Compound 4, half-maximal inhibitory concentration: 1.09 ug/mL
Estimate against measurement, compound 4: 6.0-fold (0.78 log units) above, outside the stated range (below it).
By their numbers in this assay, from the lowest: compound 4; then compounds 3 and 1 (each within the scatter of the next); then compound 2.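

In this assay, a ring on this carbonyl carbon proves unnecessary: isopropyl, with no ring and 3 heavy atoms against the 8 of 3,4-dichlorophenyl, gives a clear gain (a 3.6-fold lower number from compound 3 to compound 4 (0.55 log units; beyond the scatter)), and it also outdoes furan-2-yl on the same carbon (a 5.0-fold lower number from compound 1 to compound 4 (0.70 log units; beyond the scatter)). Among the compounds shown here, the two ring groups had stayed within the scatter of each other, so this carbon looked insensitive to what it carries, yet compound 4 now stands beyond the scatter from every other compound here, at the end of stronger inhibition, and putting isopropylcarbonyl in place of the hydrogen on the nitrogen produces the only large step in the set (an 11-fold lower number from compound 2 to compound 4 (1.02 log units; beyond the scatter)). No measurement shown here accounts for the gain.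

With only one ringless group in view, the compounds shown cannot tell whether the gain belongs to isopropyl itself or would extend to a methyl, a tert-butyl or a longer chain such as n-butyl. They also leave open how a small saturated ring such as cyclopropyl, or a chain ending in an amine or a carboxylic acid, would behave on this carbon.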